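Oxan-4-yl in place of 3-chlorophenyl on the aryl ether

This account rests on a few compounds, and the source may have more. Where it says the series, first, only, none or still open, it means among the compounds named here.

Measured so far:
compound 1, `O=C(CCCCCc1ccc(F)c(Cl)c1)N1CCOC1=O`: 26 nM
compound 2, `O=C1OCCN1C(=O)c1ccc(Oc2cccc(Cl)c2)cc1`: 7740 nM

In an assay on HEK293 cells for inhibition of N-acylethanolamine-hydrolyzing acid amidase (Rattus norvegicus), read by LC-MS, with a stated time of 30 min (a lower number here means a stronger inhibitor, a higher number a weaker inhibitor), compound 2 gives 7740 nM, the higher of the two numbers; compound 1 gives 26 nM, a far lower number, and the gap lies beyond the scatter. Compound 3, `O=C1OCCN1C(=O)c1ccc(OC2CCOCC2)cc1`, is not yet measured. It differs from compound 2 by oxan-4-yl in place of 3-chlorophenyl on an oxygen on an aromatic ring. Within the data shown here, no measured pair shows this change, so its size is unknown. The expected step of a 1.6-fold higher number from compound 2 to compound 3 (0.19 log units; within the scatter) is small, toward a higher number, and may not exceed the scatter. Compound 3 is estimated at 12000 nM, within 4000 nM to 40000 nM.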

Compound 3, half-maximal inhibitory concentration: 330 nM
For compound 3 the middle estimate is 36-fold (1.56 log units) above the measured one; measured number outside the range, below it.
By their numbers in this assay, from the lowest: compound 1; then compound 3; then compound 2.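

In this assay, the group on this oxygen strongly sets the read-out: oxan-4-yl in place of 3-chlorophenyl gives a 23-fold lower number from compound 2 to compound 3 (1.37 log units; beyond the scatter) in a single change. In this pair, an aromatic ring on the oxygen is therefore not needed for the lower number, and a non-aromatic ring with one hetero atom serves better. No available measurement bears on the cause of this step. Whether the ring oxygen of oxan-4-yl or the non-aromatic ring itself accounts for the step remains open. Cyclohexyl or piperidin-4-yl on the same oxygen would separate these two readings.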